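Removing the Nitrile: From Compound 1 to Compound 4

The compounds below may be only part of what the source reports. "The series", "measured", "known", "first", "only" and "open" are said of these compounds alone.

Measured so far:
- Compound 1, `N#Cc1cccc(NC(=O)CSc2nc3cccnc3[nH]2)c1`: 45%
- Compound 2, `COc1ccc(NC(=O)CCSc2nc3cccnc3[nH]2)cc1OC`: 13%
- Compound 3, `COc1ccc(NC(=O)C(C)Sc2nc3cccnc3[nH]2)cc1OC`: 6%

All three share the same core and were tested in an assay on isolated protein for inhibition of Ectonucleotide pyrophosphatase/phosphodiesterase family member 1 (Homo sapiens), tested at 10 uM; on this read-out lower numbers stand for less inhibition and higher numbers for more inhibition at the one concentration tested (going by the name of the read-out). Among them compound 1 stands highest; compound 2 comes nearest, with a number that lies lower by more than the usual scatter, and compound 3 lies lower still, also beyond the scatter. Compounds 2 and 3 differ from compound 1 in more than one place, so nothing can be said about which of their changes accounts for the gap; their two values are simply what they are.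

Compound 4, `O=C(CSc1nc2cccnc2[nH]1)Nc1ccccc1`, has not yet been measured in this assay. It differs from compound 1 in a single place: hydrogen in place of cyano on an aromatic carbon. The nitrile sits on the aromatic ring of carbon only, meta to a large group, and in compound 4 a hydrogen takes its place.

Among the compounds with values here, no measured pair shows what happens when this group is removed on its own, so the size of the step cannot be read from the data. Within the data shown here, compound 1 is the only compound carrying the nitrile and also the highest of the three, so some loss is expected, but of uncertain size. The step expected in this assay from compound 1 to compound 4 is a number 15 percentage points lower from compound 1 to compound 4 (beyond the scatter). Compound 4 is therefore expected to give about 30%, in a range from 10% to 50%.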

Compound 4, a percentage reported as inhibition, at one concentration (the size of the read-out at that concentration, not a potency): 30%
Compound 4: the middle estimate sits on the measured number at the digits printed, and the stated range covers the measured number.
By their numbers in this assay, from the lowest: compounds 3 and 2 (each within the scatter of the next); then compound 4; then compound 1.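

In this assay, within the data shown here, the single change of hydrogen in place of cyano on an aromatic carbon gives the first clean comparison in this set: a number 15 percentage points lower from compound 1 to compound 4 (beyond the scatter). This ties a real but modest part of the number of compound 1 to the nitrile itself, something compounds 2 and 3 could not show because they differ from compound 1 in more than one place, while compound 4 still gives 30% in this assay and so keeps a clear share of the inhibition with only hydrogen at this ring carbon. Nothing measured here explains why the number falls when the nitrile leaves.

The compounds shown leave open whether the nitrile is special at this place or whether another group, such as an amine, a carboxylic acid or a chlorine atom on the same ring carbon, would give a number that is higher, lower or level. They also leave open how these inhibition figures would translate into potency, since each one comes from a single concentration.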